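This account rests on a few compounds, and the source may have more. Where it says the series, first, only, none or still open, it means among the compounds named here.

Working notes on the series. In an ADME assay on microsomes from liver (Mus musculus) for metabolic stability, read by LC-MS, tested at 1 uM (a higher number here means faster removal of the compound, a lower number slower removal), compound 2 `CCOC(=O)C1=C(C)N/C(=C/c2cc(C)n(-c3ccc(N(C)C)cc3)c2C)C1=O` gives 56 mL.min-1.g-1, and compound 1 `CCOC(=O)C1=C(C)N/C(=C/c2cc(C)n(-c3ccc(CN(C)C)cc3)c2C)C1=O` gives 31 mL.min-1.g-1 in this assay; these two values sit within the usual scatter of one another, the step being a 1.8-fold higher number from compound 1 to compound 2 (0.26 log units; within the scatter). Compound 3 `CCOC(=O)C1=C(C)N/C(=C/c2cc(C)n(-c3cccnc3)c2C)C1=O` carries pyridin-3-yl in place of 4-(dimethylamino)phenyl on an aromatic nitrogen. Within the data shown here, no measured step exchanges this whole aryl group, and the one step available is within the scatter, so for compound 3 a step of a 1.4-fold lower number from compound 2 to compound 3 (0.15 log units; within the scatter) in this assay is expected, with wide uncertainty. The estimated value for compound 3 in this assay is 40 mL.min-1.g-1, expected to fall between 14 mL.min-1.g-1 and 115 mL.min-1.g-1.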

Compound 3, intrinsic clearance in microsomes: 82 mL.min-1.g-1
Compound 3: the middle estimate sits 2.1-fold (0.31 log units) below what was measured, within the range that was stated.
By their numbers in this assay, from the lowest: compounds 1, 2 and 3 (each within the scatter of the next, the first and the last beyond it).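

In this assay, pyridin-3-yl on the aromatic nitrogen in place of 4-(dimethylamino)phenyl gives a 1.5-fold higher number from compound 2 to compound 3 (0.17 log units; within the scatter), so this exchange of the whole aryl group is not separated from the scatter. In place of 4-((dimethylamino)methyl)phenyl, the same group gives a 2.6-fold higher number from compound 1 to compound 3 (0.42 log units; beyond the scatter), a modest step and the only one in the series beyond the scatter. Nothing measured here accounts for either step. Open, going by these compounds, is how a plain phenyl, or a phenyl bearing a carboxylic acid, on this aromatic nitrogen would compare with compound 3.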